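Tying the amine of compound 1 into a ring

A few compounds are considered here, and "the series" means these few. Any claim that something is new, unique, unknown or untested is made for them only; others in the source may bear on it.

Among the compounds with values here, only two compounds have been measured so far, which gives little to build on. In a functional assay on MDA-MB-231 cells (Homo sapiens) for antiproliferative activity, read by WST assay, with a stated time of 72 h (on this read-out higher numbers stand for weaker inhibition and lower numbers for stronger inhibition), compound 1 (`CCN(CC)CC#CCSc1nc2c(c(=O)[nH]c(=O)n2C)n1C`) gives 68100 nM, while compound 2 (`CCN(CC)CC#CCSc1nc(Cl)nc2nc(SCC#CCN(CC)CC)n(C)c12`) gives 10000 nM. Compound 1 therefore holds the higher number of the pair and is the weaker inhibitor, by a gap beyond the usual scatter of repeated measurements.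

The next candidate, compound 3 (`Cn1c(SCC#CCN2CCCC2)nc2c1c(=O)[nH]c(=O)n2C`), keeps the core of compound 1 and changes one group: pyrrolidin-1-yl in place of diethylamino on a saturated chain carbon bound to a triple-bonded carbon. In plain terms, pyrrolidin-1-yl takes the place of diethylamino on a saturated chain carbon bound to a triple-bonded carbon, so the open amine end becomes one five-membered non-aromatic ring.

Within the data shown here, no measured pair shows what this swap does, so the only anchor is compound 1 at 68100 nM. The expected 1.1-fold lower number from compound 1 to compound 3 (0.05 log units; within the scatter) is small, leaning slightly towards a lower number but staying within the scatter. Compound 3 is expected at about 60000 nM in this assay, with an estimated range of 25000 nM to 130000 nM.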

Compound 3, half-maximal inhibitory concentration: 472000 nM
Compound 3: middle estimate off by 7.9-fold (0.90 log units), on the low side, and the stated range ends below it.
By their numbers in this assay, from the lowest: compound 2; then compound 1; then compound 3.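

In this assay, tying the amine end into a ring gives a 6.9-fold higher number from compound 1 to compound 3 (0.84 log units; beyond the scatter) and so a weaker inhibitor. Within the data shown here, this is the first pair of compounds that differ in one place, and it shows that this position on a saturated chain carbon bound to a triple-bonded carbon is not indifferent to change: diethylamino and pyrrolidin-1-yl have the same counts of heavy atoms, hydrogen-bond donors and hydrogen-bond acceptors, yet the read-out moves beyond the usual scatter, so the assay responds to how the amine end is built and not only to which atoms it holds. No measurement at hand accounts for this step.

As far as these compounds go, it remains open whether the weaker result belongs to the five-membered ring in particular or to ring closure in general, which piperidin-1-yl or morpholin-4-yl in the same place could help to separate, while dimethylamino would test a shorter open amine. From the compounds shown here alone, it also remains open whether pyrrolidin-1-yl would have a similar effect on the chains of compound 2, whose core differs from that of compound 1.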